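Working notes: from compound 3 to compound 4

This account rests on a few compounds, and the source may have more. Where it says the series, first, only, none or still open, it means among the compounds named here.

Three measured compounds share one core and differ only in the aryl group attached to an aromatic carbon. Compound 1 `Cc1cc(-c2ccc(F)cc2)c(S(C)(=O)=O)cc1C(=O)N=C(N)N` gives 36 nM in a functional assay for inhibition of sodium/hydrogen exchanger (Oryctolagus cuniculus); on this read-out higher numbers stand for weaker inhibition and lower numbers for stronger inhibition. Compound 2 `Cc1cc(-c2ccco2)c(S(C)(=O)=O)cc1C(=O)N=C(N)N` gives 16 nM in this assay, a change of a 2.3-fold lower number from compound 1 to compound 2 (0.35 log units; beyond the scatter). Compound 3 `Cc1cc(Sc2ccccc2)c(S(C)(=O)=O)cc1C(=O)N=C(N)N` gives 14 nM in this assay, a change of a 2.6-fold lower number from compound 1 to compound 3 (0.41 log units; beyond the scatter); the comparison a 1.1-fold lower number from compound 2 to compound 3 (0.06 log units; within the scatter) is within the scatter. Compound 3 thus has the lowest number of the three measured, though only its gap to compound 1 is beyond the scatter, and it cannot be separated from compound 2.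

Compound 4 `Cc1cc(Oc2ccccc2Cl)c(S(C)(=O)=O)cc1C(=O)N=C(N)N` is not yet measured. Its difference from compound 3 is 2-chlorophenoxy in place of phenylsulfanyl on an aromatic carbon. Going by the values given here, no measured step replaces phenylsulfanyl with a phenoxy group or adds a chlorine, so the steps that bear on this change are those exchanging the aryl group at this position: a 2.3-fold lower number from compound 1 to compound 2 (0.35 log units; beyond the scatter), a 2.6-fold lower number from compound 1 to compound 3 (0.41 log units; beyond the scatter) and a 1.1-fold lower number from compound 2 to compound 3 (0.06 log units; within the scatter), all modest or within the scatter. Compound 4 is therefore expected to stay close to compound 3, with a step of a 1.3-fold higher number from compound 3 to compound 4 (0.11 log units; within the scatter) that is not expected to go beyond the scatter in either direction. The estimate for compound 4 in this assay is 18 nM, within 7 nM to 45 nM.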

Compound 4, half-maximal inhibitory concentration: 14 nM
For compound 4 the middle estimate is 1.3-fold (0.11 log units) above the measured one, and the stated range covers the measured number.
By their numbers in this assay, from the lowest: compounds 3, 4 and 2 (each within the scatter of the next); then compound 1.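

In this assay, the exchange on this aromatic carbon, ortho to the methylsulfonyl group, of phenylsulfanyl for 2-chlorophenoxy gives no change at the digits printed from compound 3 to compound 4 (within the scatter) and so shows that an oxygen-linked ring carrying a chlorine is accepted here as well as a sulfur-linked ring without one. The 2-chlorophenoxy group also cannot be separated from the directly attached furan-2-yl, with a 1.1-fold lower number from compound 2 to compound 4 (0.06 log units; within the scatter), while the comparison with the directly attached 4-fluorophenyl gives a 2.6-fold lower number from compound 1 to compound 4 (0.41 log units; beyond the scatter), which leaves compound 1 as the only one of the four set apart from the others, and compound 2 shows that a linking atom is not needed to stay level with compound 3 and compound 4. No measured information on hand accounts for the close agreement among compound 2, compound 3 and compound 4.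

Going by these compounds, the step to compound 4 exchanges the linking atom and adds the chlorine together, so the separate contribution of each remains open, as does the effect of moving that chlorine to another ring position. Also open, on these data alone, is how this position responds to a group without an aromatic ring, such as an amine, a carboxylic acid or a longer alkyl chain.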